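A few compounds are considered here, and "the series" means these few. Any claim that something is new, unique, unknown or untested is made for them only; others in the source may bear on it.

Within the data shown here, compound 3 `CCCCCCCCCCCCCCC[C@@H](O)[C@@H](COP(=O)(O)O)N=[N+]=[N-]` gives the highest number of the three measured so far, 28300 nM in an assay on isolated protein for inhibition of sphingosine-1-phosphate lyase 1 (Homo sapiens), read by fluorescence, with a stated time of 1 h; on this read-out higher numbers stand for weaker inhibition and lower numbers for stronger inhibition. Its nearest neighbour is compound 1 `CCCCCCCCCCCCCCC[C@H](O)[C@H](COP(=O)(O)O)N=[N+]=[N-]`, which in this assay gives 21800 nM, a gap within the scatter (a 1.3-fold higher number from compound 1 to compound 3 (0.11 log units; within the scatter)). Compound 2 `CCCCCCCCCCCCCCC[C@H](O)[C@@H](COP(=O)(O)O)N=[N+]=[N-]` stands furthest away with 10800 nM.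

Compound 4 `CCCCCCCCCCCCCCC[C@@H](O)[C@H](COP(=O)(O)O)N=[N+]=[N-]` differs from compound 3 at one place: the two compounds have the same atoms and bonds; at least one stereo element is drawn with a configuration in one of them and without one in the other: 1 of 3 stereo elements differ; a stereocentre at a saturated chain carbon is drawn R in compound 3 and S in compound 4. Among the measured compounds shown here, the steps that bear on this are the two single-stereocentre changes already measured. From compound 1 to compound 2 the number fell (a 2.0-fold lower number from compound 1 to compound 2 (0.31 log units; beyond the scatter)), and from compound 2 to compound 3 it rose (a 2.6-fold higher number from compound 2 to compound 3 (0.42 log units; beyond the scatter)). Both steps are modest and beyond the scatter, while the double change between compound 1 and compound 3 stays within it. A single flip at the azide-bearing carbon is therefore expected to move the number in this assay by a modest amount, most likely downward from compound 3.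

Compound 4 is expected to give about 16000 nM in this assay, within 7000 nM to 35000 nM, which corresponds to an estimated step of a 1.8-fold lower number from compound 3 to compound 4 (0.25 log units; within the scatter).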

Compound 4, half-maximal inhibitory concentration: 25700 nM
Compound 4: the middle estimate sits 1.6-fold (0.21 log units) below what was measured; low and high end bracket the measured number.
By their numbers in this assay, from the lowest: compound 2; then compounds 1, 4 and 3 (each within the scatter of the next).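

In this assay, inverting this stereocentre at a saturated chain carbon gives a 1.1-fold lower number from compound 3 to compound 4 (0.04 log units; within the scatter), whereas the change at the same carbon gave a 2.0-fold lower number from compound 1 to compound 2 (0.31 log units; beyond the scatter), so its effect is not constant and depends on the configuration at the other chain stereocentre. The other single change into the new compound gives a 1.2-fold higher number from compound 1 to compound 4 (0.07 log units; within the scatter), which places compounds 1, 3 and 4 together within the scatter. Compound 2 alone stands apart, now also with a 2.4-fold higher number from compound 2 to compound 4 (0.38 log units; beyond the scatter), so only one of the four configurations is separated from the rest, and the strongest inhibition in this set remains in the micromolar range, with compound 2 at 10800 nM.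

Going by these compounds, whether this dependence on configuration persists with an amine in place of the azide remains open. The same holds for a shorter chain, or for a phosphonate in place of the phosphate.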